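The source may report more compounds than this note shows. Statements on the series, on what has been measured and on what is new or still open speak of the compounds shown alone.

Values in an ADME assay on Caco-2 cells (Homo sapiens) for permeability, in the apical to basolateral direction; on this read-out lower numbers stand for lower permeability and higher numbers for higher permeability:
- compound 1 `CCCC(=O)N1CCC(CN(C2Cc3cc(C#N)ccc3N(Cc3cncn3C)C2)S(=O)(=O)c2ccccn2)CC1`: 0.5 10^-6 cm/s
- compound 2 `CCS(=O)(=O)N1CCC(CN(C2Cc3cc(C#N)ccc3N(Cc3cncn3C)C2)S(=O)(=O)c2ccccn2)CC1`: 0.1 10^-6 cm/s

Of these two compounds, compound 2 has the lower number, at 0.1 10^-6 cm/s. Compound 3 `CCOC(=O)N1CCC(CN(C2Cc3cc(C#N)ccc3N(Cc3cncn3C)C2)S(=O)(=O)c2ccccn2)CC1` differs from it in one group: ethoxycarbonyl in place of ethylsulfonyl on an amine nitrogen in a ring. The ethylsulfonyl group therefore gives way to ethoxycarbonyl on the amine nitrogen in a ring, and the rest of the molecule stays the same. Within the data shown here, only one measured step bears on this change. It touches the same nitrogen and is a 5.0-fold lower number from compound 1 to compound 2 (0.70 log units; beyond the scatter). Compound 1, at 0.5 10^-6 cm/s, carries propylcarbonyl there, so it also has a carbonyl on that nitrogen, as compound 3 does. A single step is thin evidence, but undoing the sulfonyl swap suggests a rise of similar size. The expected change is a 4.0-fold higher number from compound 2 to compound 3 (0.60 log units; beyond the scatter). The estimate for compound 3 is 0.4 10^-6 cm/s, with an expected range of 0.15 10^-6 cm/s to 1.2 10^-6 cm/s.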

Compound 3, apparent permeability: 2.6 10^-6 cm/s
The estimate for compound 3 lay 6.5-fold (0.81 log units) below the measured number; the measured number lies above the stated range.
By their numbers in this assay, from the lowest: compound 2; then compound 1; then compound 3.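

In this assay, ethoxycarbonyl in place of ethylsulfonyl on the amine nitrogen in the ring gives a 26-fold higher number from compound 2 to compound 3 (1.41 log units; beyond the scatter), so this position responds strongly to what sits on that nitrogen. The earlier compounds shown here suggested that having a carbonyl there might be enough, yet the two carbonyl compounds are themselves clearly apart, with ethoxy in place of propyl on the carbonyl carbon giving a 5.2-fold higher number from compound 1 to compound 3 (0.72 log units; beyond the scatter); the atom attached to the carbonyl carbon therefore matters as well. Nothing available here explains either rise.

A propoxycarbonyl group, with a longer chain on the oxygen, or a dimethylaminocarbonyl group, with an amine nitrogen in place of that oxygen, would test how specific the ethoxy result is. On these data alone, whether the same swap gives a similar step on a different core also remains open.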